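Naphthalen-1-yl Replaces Methoxyphenyl on a Shared Core

The source may hold more compounds than are shown below. What is called first, only, known or untested is meant among the compounds shown, and "the series" means these compounds.

Of the compounds shown here, two on a shared core have been measured. Compound 1 `N#CC1=C(N)OC(c2c[nH]c3ccccc23)=C(C#N)C1c1ccc(Br)cc1` and compound 2 `COc1ccc(C2C(C#N)=C(N)OC(c3c[nH]c4ccccc34)=C2C#N)cc1` differ only in one group on an aromatic carbon. In a functional assay, tested at 50 ug/mL (a higher number here means a stronger effect of the compound at the concentration tested, a lower number a weaker effect), compound 1 gives 14.2%, and in this assay compound 2 gives 12.4%. Among the measured compounds shown here, the step of a number 1.8 percentage points lower from compound 1 to compound 2 (within the scatter) is within the scatter, so the two numbers cannot be told apart; compound 2 thus stands beside compound 1 on the only two numbers known, both modest effects at the concentration tested.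

Compound 3 `N#CC1=C(N)OC(c2c[nH]c3ccccc23)=C(C#N)C1c1cccc2ccccc12` has not been measured yet. It differs from compound 2 as follows: naphthalen-1-yl in place of 4-methoxyphenyl on a saturated ring carbon. For the measured compounds named here, the only measured step bears on this change indirectly, since a number 1.8 percentage points lower from compound 1 to compound 2 (within the scatter) swapped one group for another inside the very 4-methoxyphenyl group that now leaves, and that swap did not move the read-out beyond the scatter. Nothing measured here shows what a naphthalen-1-yl group does on this core. Compound 3 is therefore expected to give 13%, within a range from 4% to 24%. The estimated step of a number 0.6 percentage points higher from compound 2 to compound 3 (within the scatter) is expected to stay within the scatter, in no clear direction.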

Compound 3, a percentage reported as activity, at one concentration (the size of the read-out at that concentration, not a potency): 4.7%
The estimate for compound 3 lay 8.3 percentage points above the measured number, and the stated range covers the measured number.
By their numbers in this assay, from the lowest: compounds 3, 2 and 1 (each within the scatter of the next).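

Until now only a small swap inside the aryl group on the saturated ring carbon had been measured, whereas here the whole group changes, with naphthalen-1-yl and its 2 six-membered aromatic rings entering in place of a group with one such ring. In this assay this change gives a number 7.7 percentage points lower from compound 2 to compound 3 (within the scatter) and, measured against the 4-bromophenyl group, a number 9.5 percentage points lower from compound 1 to compound 3 (within the scatter) so 4-bromophenyl, 4-methoxyphenyl and naphthalen-1-yl at this position cannot be told apart on these numbers, even with a larger aromatic group in place. No separate data on these compounds bear on this result. The compounds shown leave open whether a group without an aromatic ring on this carbon, such as cyclohexyl or a longer alkyl chain, or an aryl ring carrying an amine or a carboxylic acid, would give a number that stands clearly apart from these three. They also leave open what happens when the 1H-indol-3-yl group, the amino group or either cyano group on the shared core is replaced, for example the 1H-indol-3-yl group by a plain phenyl ring.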